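This account rests on a few compounds, and the source may have more. Where it says the series, first, only, none or still open, it means among the compounds named here.

Measured compounds:
- Compound 1 `CCOC(=O)c1cc2ccc(OCCCCCn3cc(CNC(=O)CCCCC4CCSS4)nn3)cc2oc1=O` gives 34.4% in a functional assay on PC-12 cells (Rattus norvegicus) for cytotoxicity, read by MTT assay, with stated times of 3 h and 2 h, tested at 0.1 uM; on this read-out higher numbers stand for a stronger effect at the one concentration tested and lower numbers for a weaker effect.
- Compound 2 `O=C(CCCCC1CCSS1)NCc1cn(CCCCCOc2ccc3cc(-c4ccccc4)c(=O)oc3c2)nn1` gives 35.5% in this assay.

On these two numbers compound 2 stands highest, but only barely: the step of a number 1.1 percentage points higher from compound 1 to compound 2 (within the scatter) is within the scatter, so the two compounds cannot be told apart on this read-out.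

Compound 3 `O=C(CCCCC1CCSS1)NCc1cn(CCCCCOc2ccc3cc(-c4ccc(Cl)c(Cl)c4)c(=O)oc3c2)nn1` is not yet measured. It differs from compound 2 at one spot: 3,4-dichlorophenyl in place of phenyl on an aromatic carbon.

For the measured compounds named here, no measured step touches this change. Going by the values given here, the only step available, a number 1.1 percentage points higher from compound 1 to compound 2 (within the scatter), swaps one group for another at the same aromatic carbon and produced nothing beyond the scatter. That is weak guidance, since it concerns a different pair of groups, but it shows that changing the group at this position did not shift the read-out in the one case seen. The expectation for compound 3 is therefore a step of a number 1.5 percentage points higher from compound 2 to compound 3 (within the scatter), that is, no movement beyond the usual scatter in this assay. Compound 3 is estimated at 37%, with a range from 25% to 49%.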

Compound 3, a percentage reported as activity, at one concentration (the size of the read-out at that concentration, not a potency): 39.7%
Beside the measured number, compound 3's estimate is 2.7 percentage points below it; low and high end bracket the measured number.
By their numbers in this assay, from the lowest: compounds 1, 2 and 3 (each within the scatter of the next).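

Putting 3,4-dichlorophenyl in place of phenyl on this aromatic carbon gives a number 4.2 percentage points higher from compound 2 to compound 3 (within the scatter) in this assay, so adding the two chlorine atoms to the ring does not separate these two compounds on this read-out. The direct exchange of ethoxycarbonyl for 3,4-dichlorophenyl at the same carbon gives a number 5.3 percentage points higher from compound 1 to compound 3 (within the scatter), which means that all three groups now seen at this position, ethoxycarbonyl, phenyl and 3,4-dichlorophenyl, give numbers that cannot be told apart at the one concentration tested. No measurement shown here offers an explanation for this result.

Going by these compounds, it remains open whether a different kind of group on this aromatic carbon, such as an amine or a carboxylic acid, would give a step beyond the scatter. Also open, on these data alone, are whether a longer chain between the shared core and the rest of the molecule would change the number, and whether these three compounds would still be indistinguishable at other concentrations.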